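EP4 binding: aryl tail change on a lactam acid

The source may hold more compounds than are shown below. What is called first, only, known or untested is meant among the compounds shown, and "the series" means these compounds.

Measured so far: compound 1 `O=C(O)CCCCCCN1C(=O)CCC1CCC(O)CCc1ccccc1`, compound 2 `O=C(O)CCCCCCN1C(=O)CC[C@@H]1CC[C@@H](O)CCc1ccccc1`, compound 3 `O=C(O)c1ccc(CCCN2C(=O)CC[C@@H]2CC[C@@H](O)Cc2cccc(C(F)(F)F)c2)cc1`.

In an assay on HEK293 cells for binding affinity to prostaglandin E2 receptor EP4 subtype (Rattus norvegicus) (on this read-out lower numbers stand for stronger inhibition and higher numbers for weaker inhibition), compound 1 gives only a limit, > 3200 nM. Compound 2 gives 2710 nM and compound 3 gives 70 nM. Compound 2 stands highest of the two numbers given; compound 3 is the nearest and sits far lower. Among the measured compounds shown here, the one step between measured compounds is an at least 1.1-fold lower number from compound 1 to compound 2 (0.07 log units; that floor lies within the scatter), which rests on the limit of > 3200 nM in this assay, at which 1 of the 3 values shown sits, and the fact that one of compounds 1 and 2 is drawn with a defined configuration and the other without, at the place where they differ and says little.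

Compound 4 `N#Cc1cccc(C[C@H](O)CC[C@H]2CCC(=O)N2CCCCCCC(=O)O)c1` differs from compound 2 by 3-cyanophenyl in place of benzyl on a saturated chain carbon, two bonds along the chain from an oxygen on a saturated carbon. For the measured compounds named here, no measured step touches that change; compound 3 carries a different aryl substituent together with other changes, so only its value is known. A modest improvement is expected: a 3.0-fold lower number from compound 2 to compound 4 (0.48 log units; beyond the scatter), giving compound 4 an estimated 900 nM (range 200 nM to 3200 nM).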

Compound 4, half-maximal inhibitory concentration: 388 nM
Compound 4: the middle estimate sits 2.3-fold (0.37 log units) above what was measured, within the range that was stated.
By their numbers in this assay, from the lowest: compound 3; then compound 4; then compound 2. At a limit, above all of these: compound 1.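

Within this assay, 3-cyanophenyl in place of benzyl on a saturated chain carbon, two bonds along the chain from an oxygen on a saturated carbon, gives a 7.0-fold lower number from compound 2 to compound 4 (0.84 log units; beyond the scatter). Among the compounds shown here, this is the first single-place step that lies beyond the scatter, so this position affects binding while the rest of compound 2 stays unchanged. Nothing shown gives a reason for the step.

Read one bond further out, phenethyl to 3-cyanobenzyl, the change combines the nitrile with a change of link to the ring, and the compounds shown do not separate the two. Unsubstituted benzyl in that same cut would separate them.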